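Benzyl and phenyl amides: estimating compound 4

The source may hold more compounds than are shown below. What is called first, only, known or untested is meant among the compounds shown, and "the series" means these compounds.

Values in an ADME assay on HepG2 2.2.15 cells (Homo sapiens) for cytotoxicity, read by MTT assay, with stated times of 48 h and 9 days; on this read-out lower numbers stand for higher toxicity in this test and higher numbers for lower toxicity in this test:
- compound 1 `COc1ccc2c(=O)c(/C=C/C(=O)Nc3cccc(Cl)c3)coc2c1`: 1100000 nM
- compound 2 `COc1ccc(CNC(=O)/C=C/c2coc3cc(OC)ccc3c2=O)cc1`: 43000 nM
- compound 3 `COc1ccc2c(=O)c(/C=C/C(=O)Nc3ccccc3OC)coc2c1`: 1050000 nM

Two values share the high end of this assay, with a 1.0-fold lower number from compound 1 to compound 3 (0.02 log units; within the scatter). The 4-methoxybenzyl amide stands apart, with a 26-fold lower number from compound 1 to compound 2 (1.41 log units; beyond the scatter) and a 24-fold higher number from compound 2 to compound 3 (1.39 log units; beyond the scatter).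

The next change is 2,4-difluorobenzyl in place of 2-methoxyphenyl on an amide-type nitrogen, giving compound 4 `COc1ccc2c(=O)c(/C=C/C(=O)NCc3ccc(F)cc3F)coc2c1`. Compound 2 is the only measured benzyl amide, so this expectation rests on a single case, and no fluorinated benzyl has been measured. A large drop is expected, though probably smaller than a 24-fold higher number from compound 2 to compound 3 (1.39 log units; beyond the scatter) in size. The expected step is a 12-fold lower number from compound 3 to compound 4 (1.07 log units; beyond the scatter). The estimated value for compound 4 is 90000 nM, with an expected range of 20000 nM to 500000 nM.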

Compound 4, half-maximal cytotoxic concentration: 79300 nM
Estimate against measurement, compound 4: 1.1-fold (0.05 log units) above; measured number inside the range.
By their numbers in this assay, from the lowest: compounds 2 and 4 (each within the scatter of the next); then compounds 3 and 1 (each within the scatter of the next).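

In this assay the step of a 13-fold lower number from compound 3 to compound 4 (1.12 log units; beyond the scatter) and the step of a 14-fold lower number from compound 1 to compound 4 (1.14 log units; beyond the scatter) put a second benzyl amide at the low end, with 2,4-difluorobenzyl on the amide-type nitrogen. The step of a 1.8-fold higher number from compound 2 to compound 4 (0.27 log units; within the scatter) keeps the two benzyl amides together with 2,4-difluorophenyl in place of 4-methoxyphenyl, so across these four compounds the split runs between phenyl and benzyl amides, and none goes against it. No measured evidence bears on what lies behind this split.

Two compounds on each side make a narrow base for that split. Open, from the compounds shown here alone, is whether an unsubstituted benzyl, a longer chain before the ring, or an amine on that chain would stay with the benzyl amides.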